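A Longer Side Chain on the Weakest Aortic Inhibitor

This account rests on a few compounds, and the source may have more. Where it says the series, first, only, none or still open, it means among the compounds named here.

Of the compounds shown here, two sharing one core have been measured in a functional assay (aorta) with Oryctolagus cuniculus as the target; a higher number here means a weaker inhibitor, a lower number a stronger inhibitor. Compound 1 `Fc1ccccc1Cn1nc(-c2ccccn2)c2cccnc21` carries a pyridyl group on the core and gives 4800 nM in this assay. Within the data shown here, compound 2 `CCCc1cnc(-c2nn(Cc3ccccc3F)c3ncccc23)nc1N` replaces that group with an aminopyrimidine bearing a propyl chain and gives 252000 nM in this assay, the higher of the two numbers and thus the weaker of the pair; its gap to compound 1, the only neighbour, lies well beyond the scatter of repeated measurements.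

Compound 3 `CC(C#N)CCCCCc1cnc(-c2nn(Cc3ccccc3F)c3ncccc23)nc1N` is the next step. It differs from compound 2 in a single place: 3-cyanobutyl in place of hydrogen on a saturated chain carbon, three bonds along the chain from an aromatic carbon. No step between two measured compounds isolates a change of this kind, so there is no shown precedent for its size or direction. The expectation is therefore cautious: the step from compound 2 to compound 3 in this assay is estimated at a 1.7-fold lower number from compound 2 to compound 3 (0.23 log units; within the scatter), close to no change beyond the scatter, with a slight lean towards a lower number. For compound 3 the estimated value in this assay is 150000 nM, with a range from 40000 nM to 600000 nM.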

Compound 3, half-maximal inhibitory concentration: 1290000 nM
Compound 3: middle estimate off by 8.6-fold (0.93 log units), on the low side; the measured number lies above the stated range.
By their numbers in this assay, from the lowest: compound 1; then compound 2; then compound 3.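

In this assay, among these compounds, the change from the propyl chain of compound 2 to the longer chain of compound 3 gives the first measured step at this position: 3-cyanobutyl in place of hydrogen on a saturated chain carbon, three bonds along the chain from an aromatic carbon, goes with a 5.1-fold higher number from compound 2 to compound 3 (0.71 log units; beyond the scatter). This step lies beyond the scatter and runs towards a weaker inhibitor, so in this assay the position is not indifferent to a substituent of this kind. No measured information on the compounds bears on this step, and the data offer no explanation for it.

With only this one step, the compounds shown cannot separate the effect of the added chain from that of its nitrile; a plain longer alkyl chain without the nitrile, or a chain of similar length carrying an amine or a carboxylic acid in its place, would be needed to do so. They also leave open whether a smaller group at this place, such as a methyl or a hydroxyl, would move the number in the same direction.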